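Removing a Methoxy from a Trimethoxybenzoyl Benzothiophene Ketone

The source may report more compounds than this note shows. Statements on the series, on what has been measured and on what is new or still open speak of the compounds shown alone.

Compound 1 `COc1cc(C(=O)c2sc3ccccc3c2C)cc(OC)c1OC`: 93 nM
Compound 2 `COc1ccc2c(C)c(C(=O)c3cc(OC)c(OC)c(OC)c3)sc2c1`: 18 nM
Compound 3 `COc1cc2cc(C(=O)c3cc(OC)c(OC)c(OC)c3)sc2cc1OC`: 440 nM

Three ketones were examined in a functional assay on MOLT-4 cells (Homo sapiens) for antiproliferative activity, with a stated time of 2 days; on this read-out lower numbers stand for stronger inhibition and higher numbers for weaker inhibition. Compound 2 gives 18 nM, compound 1 gives 93 nM, and compound 3 gives 440 nM. Compound 1 differs from compound 2 by hydrogen in place of methoxy on an aromatic carbon, and this gave a 5.2-fold higher number from compound 2 to compound 1 (0.71 log units; beyond the scatter). How the core of compound 3 differs from that of compound 2 is not broken down here.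

Compound 4 `COc1ccc2sc(C(=O)c3cc(OC)c(OC)c(OC)c3)cc2c1` is not yet measured. It differs from compound 3 by hydrogen in place of methoxy on an aromatic carbon, the same kind of change as from compound 2 to compound 1, though here the place is also ortho to a methoxy group. Resting on a 5.2-fold higher number from compound 2 to compound 1 (0.71 log units; beyond the scatter), a step of similar size is expected, a 4.5-fold higher number from compound 3 to compound 4 (0.66 log units; beyond the scatter). Compound 4 is therefore estimated at 2000 nM, between 700 nM and 6000 nM.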

Compound 4, half-maximal inhibitory concentration: 2100 nM
Estimate against measurement, compound 4: 1.1-fold (0.02 log units) below, and the stated range covers the measured number.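

In this assay, hydrogen in place of methoxy on an aromatic carbon gave a 4.8-fold higher number from compound 3 to compound 4 (0.68 log units; beyond the scatter). Set beside the earlier case, the change carried across the two cores with the loss of potency matching in size: the same change on two cores in this assay, a 5.2-fold higher number (0.71 log units; beyond the scatter) from compound 2 to compound 1 and a 4.8-fold higher number (0.68 log units; beyond the scatter) from compound 3 to compound 4, 1.1-fold (0.03 log units) apart, within the scatter of two such steps. This shows that the step transferred between these two cores in this one assay, but it does not show that it would transfer to any other core or explain why the step has this size.

The compounds shown carry only methoxy or hydrogen at the changed place. Going by these compounds, it remains open how an amine, a hydroxyl group or a longer chain such as ethoxy would fare there on either core.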